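The compounds below may be only part of what the source reports. "The series", "measured", "known", "first", "only" and "open" are said of these compounds alone.

Measured so far, in an assay on HeLa cells for displacement of a labelled ligand from 5-hydroxytryptamine receptor 6 (Homo sapiens); a higher number here means a weaker inhibitor, a lower number a stronger inhibitor:

Compound 1 `O=S(=O)(c1cccc(F)c1)c1cn(C2CCNC2)c2ncccc12` gives 2.7 nM.
Compound 2 `CN1CCC(n2cc(S(=O)(=O)c3cccc(F)c3)c3cccnc32)C1` gives 1.4 nM.

For the measured compounds named here, compound 2 stands at the low end of these two numbers, yet the only measured step, a 1.9-fold lower number from compound 1 to compound 2 (0.29 log units; within the scatter), lies within the scatter, so the two cannot be told apart.

Compound 3 `CCN1CCC(n2cc(S(=O)(=O)c3cccc(F)c3)c3cccnc32)C1` differs from compound 2 by methyl in place of hydrogen on a saturated chain carbon bound to an amine nitrogen in a ring. Going by the values given here, no measured step concerns this carbon; the one step in hand, a 1.9-fold lower number from compound 1 to compound 2 (0.29 log units; within the scatter), touched the nitrogen and stayed within the scatter. Compound 3 is therefore expected to move no further than the scatter, a 1.3-fold higher number from compound 2 to compound 3 (0.11 log units; within the scatter), and is estimated at 1.8 nM, ranging from 0.6 nM to 5.5 nM.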

Compound 3, inhibition constant: 8.3 nM
Beside the measured number, compound 3's estimate is 4.6-fold (0.66 log units) below it, outside the stated range (above it).
By their numbers in this assay, from the lowest: compounds 2 and 1 (each within the scatter of the next); then compound 3.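

In this assay, the amine nitrogen in the ring does not accept every small group equally: changing methyl to ethyl gives a 5.9-fold higher number from compound 2 to compound 3 (0.77 log units; beyond the scatter). Ethyl also stands apart from hydrogen on the same nitrogen, with a 3.1-fold higher number from compound 1 to compound 3 (0.49 log units; beyond the scatter), although hydrogen and methyl could not be told apart. The single added carbon of ethyl thus produces a change beyond the scatter where methyl did not.

No evidence is at hand on what lies behind this. From the compounds shown here alone, whether a longer chain such as propyl, or a ring such as cyclopropyl, would raise the number further remains open.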